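Configuration step from compound 3 to compound 4

The source may hold more compounds than are shown below. What is called first, only, known or untested is meant among the compounds shown, and "the series" means these compounds.

Measured so far in a functional assay on MCF7 cells (Homo sapiens) for antiproliferative activity, read by MTT assay, with a stated time of 24 h (on this read-out higher numbers stand for weaker inhibition and lower numbers for stronger inhibition), for this series:
- compound 1 (`CCn1c(C(=O)NCCC(=O)OC)ccc1C(CC)(CC)c1ccc(OCS(=O)(=O)c2ccccc2)c(C)c1`) gives > 50000 nM as a limit
- compound 2 (`CCn1c(C(=O)N[C@@H](CC(=O)OC)C(=O)OC)ccc1C(CC)(CC)c1ccc(OCS(=O)(=O)c2ccccc2)c(C)c1`) gives > 50000 nM as a limit
- compound 3 (`CCn1c(C(=O)N[C@@H](C)CO)ccc1C(CC)(CC)c1ccc(OCS(=O)(=O)c2ccccc2)c(C)c1`) gives 10800 nM as a number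

Within the data shown here, compound 3 at 10800 nM holds the only true number in the set. The other two values are limits. Two steps lead to it, both beyond the scatter: an at least 4.6-fold lower number from compound 1 to compound 3 (0.66 log units; beyond the scatter) and an at least 4.6-fold lower number from compound 2 to compound 3 (0.66 log units; beyond the scatter) in this series. Their sizes are bounded by the limit of > 50000 nM in this assay, at which 2 of the 3 values shown sit, and are not full sizes. The remaining step is a step that the two limits leave unreadable from compound 1 to compound 2 and adds nothing here.

Compound 4 (`CCn1c(C(=O)N[C@H](C)CO)ccc1C(CC)(CC)c1ccc(OCS(=O)(=O)c2ccccc2)c(C)c1`) is the next to read against compound 3 (the two compounds have the same atoms and bonds and differ only in configuration as drawn: 1 of 1 stereo elements differ; a stereocentre at a saturated chain carbon is drawn S in compound 3 and R in compound 4). The two readable steps replace the whole group on the amide-type nitrogen, so they give no size for a change of configuration alone. Among the measured compounds shown here, no measured pair isolates such a change. The expectation therefore rests on compound 3 at 10800 nM and no change beyond the scatter is expected. The expected result is a 1.1-fold higher number from compound 3 to compound 4 (0.05 log units; within the scatter) in this assay on this estimate. The estimate for compound 4 is 12000 nM with an expected range from 5000 nM to 35000 nM for the coming reading.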

Compound 4, half-maximal inhibitory concentration: 10600 nM
Estimate against measurement, compound 4: 1.1-fold (0.05 log units) above; low and high end bracket the measured number.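

In this assay, this pair gives the first reading of configuration alone at the saturated chain carbon of the 1-(hydroxymethyl)ethyl group, which none of the earlier pairs could give: the fact that compounds 3 and 4 differ only in the configuration as drawn

The result, a 1.0-fold lower number from compound 3 to compound 4 (0.01 log units; within the scatter), shows that the S and R forms as drawn cannot be told apart at this position in this assay. The lower numbers against the two methoxycarbonyl-bearing groups now appear with both configurations, as an at least 4.7-fold lower number from compound 1 to compound 4 (0.67 log units; beyond the scatter) and an at least 4.7-fold lower number from compound 2 to compound 4 (0.67 log units; beyond the scatter), and both steps are minimum sizes, not full sizes: the limit of > 50000 nM in this assay, at which 2 of the 4 values shown sit.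

Going by these compounds, each of these steps replaces the whole group on the amide-type nitrogen, and which part of that replacement goes with the lower numbers remains open. On these data alone, a carboxylic acid or an amine in place of the hydroxyl, or a longer chain carrying the hydroxyl, would bear on that question, and whether configuration at this carbon still gives no step beyond the scatter with such groups is also open.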